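Swapping Ethoxy for Methoxy at the Assay Limit

A few compounds are considered here, and "the series" means these few. Any claim that something is new, unique, unknown or untested is made for them only; others in the source may bear on it.

In an ADME assay on KB cells (Homo sapiens) for cytotoxicity (a lower number here means that less compound is needed, a higher number that more compound is needed for the effect), compound 3 `CCOc1c(OC)c(OC)cc2c1C(=O)[C@]1(OC)C=C[C@H]2N(C(=O)OCC(C)C)N1C(=O)OCC(C)C` gives only the limit > 300 ug/mL and no exact number. Compound 2 `COC(=O)N1[C@@H]2C=C[C@@](OC)(C(=O)c3c2cc(OC)c(OC)c3OCc2ccccc2)N1C(=O)OC` likewise gives only the limit > 300 ug/mL and no exact number. Compound 1 `CCOC(=O)N1[C@@H]2C=C[C@@](OC)(C(=O)c3c2cc(OC)c(OC)c3OCc2ccc(F)cc2)N1C(=O)OCC` reads 51.8 ug/mL as a true number. Compound 4 `COc1cc2c(c(OC)c1OC)C(=O)[C@]1(OC)C=C[C@H]2N(C(=O)OCC(C)C)N1C(=O)OCC(C)C` comes from compound 3 by one small edit (hydrogen in place of methyl on a saturated chain carbon bound to an oxygen on an aromatic ring) with hydrogen in place of methyl on a saturated chain carbon bound to an oxygen on an aromatic ring, turning ethoxy into methoxy. For the measured compounds named here, no measured pair shows this edit alone, so no shift beyond the scatter is expected in this assay and no direction is favoured. This expectation rests on compound 3 with its limit > 300 ug/mL as the starting point. The expected step of a number no higher from compound 3 to compound 4 (the limit leaves the size open) is therefore small. Compound 4 is estimated at 300 ug/mL with an expected range of 80 ug/mL to 600 ug/mL and may again return only a limit.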

Compound 4, concentration for half-maximal effect: > 300 ug/mL
Compound 4 ended at the assay's limit; the forecaster's own chance of this, stated with the estimate: 65%; the middle value lies on the limit itself.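

For the compounds shown here, compound 3 and compound 4 both return only a limit, and no step between them can be read. The compounds shown leave open whether turning ethoxy into methoxy shifts the concentration needed in this assay at all.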